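The source may report more compounds than this note shows. Statements on the series, on what has been measured and on what is new or still open speak of the compounds shown alone.

Working notes on the series. Compound 1 `Cc1ccc(C)c(S(=O)(=O)n2c(-c3cn(-c4ccccc4)nc3-c3ccc(F)cc3)nc3ccccc32)c1` bears a (2,5-dimethylphenyl)sulfonyl group and a 4-fluorophenyl; in a functional assay on HepG2 cells (Homo sapiens) for antiproliferative activity, read by MTT assay, with a stated time of 24 h (a lower number here means a stronger inhibitor, a higher number a weaker inhibitor), compound 1 gives 410 nM. Compound 2 `O=[N+]([O-])c1ccc(S(=O)(=O)n2c(-c3cn(-c4ccccc4)nc3-c3ccc(F)cc3)nc3ccccc32)cc1` differs from compound 1 by 4-nitrophenyl in place of 2,5-dimethylphenyl on a sulfonyl sulfur; in this assay compound 2 gives 1340 nM, and the step is a 3.3-fold higher number from compound 1 to compound 2 (0.51 log units; beyond the scatter). Compound 3 `Cc1ccc(C)c(S(=O)(=O)n2c(-c3cn(-c4ccccc4)nc3-c3ccc(C(F)(F)F)cc3)nc3ccccc32)c1` differs from compound 1 by trifluoromethyl in place of fluoro on an aromatic carbon; in this assay compound 3 gives 330 nM, and the step of a 1.2-fold lower number from compound 1 to compound 3 (0.09 log units; within the scatter) does not separate the two.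

Compound 4 `O=[N+]([O-])c1ccc(S(=O)(=O)n2c(-c3cn(-c4ccccc4)nc3-c3ccc(C(F)(F)F)cc3)nc3ccccc32)cc1` is not yet measured. It differs from compound 3 by 4-nitrophenyl in place of 2,5-dimethylphenyl on a sulfonyl sulfur, the change that also carries compound 1 to compound 2; the place of the change reads the same word for word in both pairs, so it is the same change, occurring twice among these compounds. The two cores differ by trifluoromethyl in place of fluoro on an aromatic carbon.

Among the compounds with values here, the step from compound 3 to compound 4 in this assay is expected to be a 3.3-fold higher number from compound 3 to compound 4 (0.52 log units; beyond the scatter) because a 3.3-fold higher number from compound 1 to compound 2 (0.51 log units; beyond the scatter) is the only precedent for this change. Compound 4 is thus estimated at 1100 nM. For compound 4 the likely range runs from 500 nM to 2500 nM.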

Compound 4, half-maximal inhibitory concentration: 1070 nM
The estimate for compound 4 lay 1.0-fold (0.01 log units) above the measured number; measured number inside the range.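

In this assay the sulfonyl change gives a 3.2-fold higher number from compound 3 to compound 4 (0.51 log units; beyond the scatter), and it carries over from the core of compound 1 to the core of compound 3 with no difference in the size of the step: the same change on two cores in this assay, a 3.3-fold higher number (0.51 log units; beyond the scatter) from compound 1 to compound 2 and a 3.2-fold higher number (0.51 log units; beyond the scatter) from compound 3 to compound 4, 1.0-fold (0.00 log units) apart, within the scatter of two such steps. The trifluoromethyl change gives a 1.3-fold lower number from compound 2 to compound 4 (0.10 log units; within the scatter), and it reads the same with either sulfonyl group: the same change on two cores in this assay, a 1.2-fold lower number (0.09 log units; within the scatter) from compound 1 to compound 3 and a 1.3-fold lower number (0.10 log units; within the scatter) from compound 2 to compound 4, 1.0-fold (0.00 log units) apart, within the scatter of two such steps. This agreement rests on four compounds, two cores and one pair of sulfonyl groups in one cell assay, so it shows that the two changes carry over within this set, not that they do so across the wider series, and it gives no explanation for the size of either step.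

Going by these compounds, it remains open whether the step holds with an alkyl chain or an amine-bearing phenyl in place of 4-nitrophenyl on a sulfonyl sulfur. Also open, on these data alone, is what a chloro or methoxy group would do in place of fluoro on an aromatic carbon.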